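This account rests on a few compounds, and the source may have more. Where it says the series, first, only, none or still open, it means among the compounds named here.

Of the compounds shown here, two have been measured in an assay for inhibition of RAC-alpha serine/threonine-protein kinase (Homo sapiens), read by HTRF, with a stated time of 1 h (a lower number here means a stronger inhibitor, a higher number a weaker inhibitor), so far. Compound 1 `Cn1ncc(Cl)c1-c1cc(C(=O)NC2CNCCC2c2ccc(C(F)(F)F)cc2)oc1Cl` gives 7.2 nM. Compound 2 `Cn1ncc(Cl)c1-c1cc(C(=O)N[C@@H]2CN[C@H](CCNS(C)(=O)=O)C[C@H]2c2ccc(F)c(F)c2)oc1Cl` gives 3.29 nM. Of these two numbers, compound 2 has the lower one, and its gap to compound 1 lies beyond the usual scatter of such measurements, so compound 2 is the stronger inhibitor of the pair.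

Compound 3 `CC(=O)NCC[C@@H]1C[C@@H](c2ccc(F)c(F)c2)[C@H](NC(=O)c2cc(-c3c(Cl)cnn3C)c(Cl)o2)CN1` has not yet been measured. It differs from compound 2 in a single place: acetyl in place of methylsulfonyl on an amine nitrogen. Everything else, including the shared core and the substituted piperidine bearing the amide, stays the same.

Among the compounds with values here, no step between measured compounds shows what this swap does; compound 1 carries no such chain at all, so no direct guide to the direction exists. Without one, the change is expected to be small, with no difference beyond the scatter; the step expected in this assay is a 1.2-fold higher number from compound 2 to compound 3 (0.08 log units; within the scatter). Compound 3 is therefore estimated at 4 nM, with a likely range from 1.5 nM to 12 nM.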

Compound 3, half-maximal inhibitory concentration: 2.49 nM
For compound 3 the middle estimate is 1.6-fold (0.21 log units) above the measured one; the measured number falls inside the stated range.
By their numbers in this assay, from the lowest: compounds 3 and 2 (each within the scatter of the next); then compound 1.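

In this assay, replacing methylsulfonyl with acetyl on the amine nitrogen of the side chain gives a 1.3-fold lower number from compound 2 to compound 3 (0.12 log units; within the scatter) and this step stays within the scatter, so the two compounds cannot be told apart by this read-out. Within the data shown here, this is the first direct view of this position: compound 2 at 3.29 nM and compound 3 at 2.49 nM show that inhibition holds when methylsulfonyl, with 4 heavy atoms and 2 hydrogen-bond acceptors, gives way to acetyl, with 3 heavy atoms and 1 hydrogen-bond acceptor. No measurement shown here offers an explanation for this result.

The compounds shown do not tell whether this position needs either group, since they offer no plain amine, with the amine nitrogen left uncapped, and no carboxylic acid or longer chain in its place. Compound 1 differs from both compounds in more than one place, so it cannot show what the 2-acetamidoethyl or 2-(methanesulfonamido)ethyl chain alone contributes.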